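From 3-hydroxycyclopentyl to 4-methoxycyclohexyl

The compounds below may be only part of what the source reports. "The series", "measured", "known", "first", "only" and "open" are said of these compounds alone.

Compound 1 `Nc1ncnc2c1c(Oc1cc(C(F)(F)F)ccn1)nn2C1CCCC1`: 0.333 h
Compound 2 `Nc1ncnc2c1c(Oc1cc(C(F)(F)F)ccn1)nn2[C@H]1CC[C@H](CO)CC1`: > 2.41 h (a limit)
Compound 3 `Nc1ncnc2c1c(Oc1cc(C(F)(F)F)ccn1)nn2C1CCC(O)C1`: > 2.41 h (a limit)

In an ADME assay on microsomes from liver (Homo sapiens) for metabolic stability, read by LC-MS, using NADPH, with a stated time of 10 min, tested at 10 uM (on this read-out higher numbers stand for a longer-lived compound and lower numbers for a shorter-lived compound), compound 1 gives 0.333 h. Compound 3 gives > 2.41 h, which is a limit of the assay and not a number. It therefore stands at the limit of > 2.41 h in this assay, at which 2 of the 3 values shown sit.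

Compound 4 `CO[C@H]1CC[C@H](n2nc(Oc3cc(C(F)(F)F)ccn3)c3c(N)ncnc32)CC1` is the next structure to consider. It carries 4-methoxycyclohexyl in place of 3-hydroxycyclopentyl on an aromatic nitrogen. The oxygen stays, but the hydroxy gives way to a methoxy, and the five-membered ring gives way to a six-membered one.

For the measured compounds named here, two measured steps bear on this change, and both lie beyond the scatter. The first is an at least 7.2-fold higher number from compound 1 to compound 2 (0.85 log units; beyond the scatter). The second is an at least 7.2-fold higher number from compound 1 to compound 3 (0.85 log units; beyond the scatter). Each replaces the cyclopentyl of compound 1 with a group carrying a hydroxy. The comparison between the two hydroxy compounds gives no size, as it is a step that the two limits leave unreadable from compound 2 to compound 3.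

Going by the values given here, no measured compound carries a methoxy, so the gain seen in an at least 7.2-fold higher number from compound 1 to compound 3 (0.85 log units; beyond the scatter) may be expected to carry over only in part. The expected change in this assay is an at least 2.0-fold lower number from compound 3 to compound 4 (0.30 log units; that floor lies within the scatter). For compound 4 the estimated value is 1.2 h, with an expected range from 0.4 h to 3.5 h.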

Compound 4, half-life: > 2.41 h
Compound 4: only a limit was reported (the forecaster's own chance of this, stated with the estimate: 30%); middle value at least 2.0-fold (0.30 log units) from the limit.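

In this assay, compound 4 gives > 2.41 h, which is a limit of the assay and not a number. The readable change is an at least 7.2-fold higher number from compound 1 to compound 4 (0.85 log units; beyond the scatter), so on the aromatic nitrogen a ring oxygen group with 0 hydrogen-bond donors, the methoxy of 4-methoxycyclohexyl, goes with the same kind of gain over cyclopentyl as the hydroxy-bearing groups of compound 2 and compound 3. The steps among compound 2, compound 3 and compound 4 cannot be read, so this series gives no order among the three oxygen-bearing groups, and all that can be said is where they sit: the limit of > 2.41 h in this assay, at which 3 of the 4 values shown sit.

The step to compound 4 changes the ring size and adds the oxygen at once, so the compounds shown do not say how much of this gain belongs to each of the two changes, and a plain cyclohexyl with no oxygen would separate them. On these data alone, whether oxygen is needed at all also stays open, and an amine or a nitrile on the cyclohexyl ring in place of the methoxy would bear on that question.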